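The source may report more compounds than this note shows. Statements on the series, on what has been measured and on what is new or still open speak of the compounds shown alone.

Compound 1 `CC(=O)OC[C@H]1O[C@@H](n2cc(CN3C(=O)/C(=C/c4ccccc4)c4ccccc43)nn2)[C@H](OC(C)=O)[C@@H](OC(C)=O)[C@@H]1OC(C)=O`, compound 2 `CC(=O)OC[C@H]1O[C@@H](n2cc(CN3C(=O)/C(=C/c4ccc(C)cc4)c4ccccc43)nn2)[C@H](OC(C)=O)[C@@H](OC(C)=O)[C@@H]1OC(C)=O` and compound 3 `CC(=O)OC[C@H]1O[C@@H](n2cc(CN3C(=O)/C(=C/c4cccs4)c4ccccc43)nn2)[C@H](OC(C)=O)[C@@H](OC(C)=O)[C@@H]1OC(C)=O` share one core and differ only in the group on a double-bonded chain carbon bound to a double-bonded ring carbon. In an ADME assay on NIH3T3 cells (Homo sapiens) for cytotoxicity, read by sulforhodamine B assay, with a stated time of 48 h (on this read-out higher numbers stand for weaker inhibition and lower numbers for stronger inhibition), compound 1 gives > 100000 nM, which is a limit of the assay rather than a number. Compound 2 gives 73300 nM. Compound 3 gives 48100 nM, the lowest of the two numbers shown, with compound 2 close to it. The step of an at least 1.3-fold lower number from compound 1 to compound 2 (0.13 log units; that floor lies within the scatter), the step of an at least 2.0-fold lower number from compound 1 to compound 3 (0.31 log units; beyond the scatter) and the step of a 1.5-fold lower number from compound 2 to compound 3 (0.18 log units; within the scatter) describe these differences. Compound 4 `CCC/C=C1/C(=O)N(Cc2cn([C@@H]3O[C@H](COC(C)=O)[C@@H](OC(C)=O)[C@H](OC(C)=O)[C@H]3OC(C)=O)nn2)c2ccccc21` arises from compound 3 by propyl in place of thiophen-2-yl on a double-bonded chain carbon bound to a double-bonded ring carbon. Among the measured compounds shown here, the steps that end at compound 3 concern the same place, but each exchanges one aromatic ring for another; none exchanges a ring for a chain, so no measured step covers this change directly, and the cytotoxicity numbers seen so far span only a narrow band. The number for compound 4 is therefore expected to shift by a 1.5-fold higher number from compound 3 to compound 4 (0.16 log units; within the scatter), with no clear direction. Compound 4 is estimated at 70000 nM, between 30000 nM and 150000 nM.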

Compound 4, half-maximal inhibitory concentration: > 100000 nM
Compound 4 gave a limit, no number; the forecaster's own chance of this, stated with the estimate: 35%; at least 1.4-fold (0.15 log units) between middle value and limit.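

Among the compounds shown, only compound 4 carries a chain rather than an aromatic ring on a double-bonded chain carbon bound to a double-bonded ring carbon, and its result is a limit of the assay, not a number. In this assay, propyl in place of thiophen-2-yl gives an at least 2.0-fold higher number from compound 3 to compound 4 (0.31 log units; beyond the scatter), so this exchange of ring for chain moves the number clearly away from the value of the thiophene, while propyl in place of 4-methylphenyl gives an at least 1.3-fold higher number from compound 2 to compound 4 (0.13 log units; that floor lies within the scatter), which does not separate the two. The step joining compound 1 and compound 4 cannot be read because both stand at the same limit: the limit of > 100000 nM in this assay, at which 2 of the 4 values shown sit.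

As far as these compounds go, whether a longer chain, or a chain carrying an amine, would give a readable number at this place stays open. So does how far compound 1 and compound 4 lie past the limit.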